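A few compounds are considered here, and "the series" means these few. Any claim that something is new, unique, unknown or untested is made for them only; others in the source may bear on it.

Measured so far:
- compound 1 `COc1ccc(OC)c(C2CC(c3ccccn3)=NN2)c1`: 15%
- compound 2 `CN(C)c1ccc(C2CC(c3ccccn3)=NN2c2ccccc2)cc1`: 35%
- compound 3 `COc1ccc(OC)c(C2CC(c3cccnc3)=NN2)c1`: 15%

These three were tested in a functional assay on the whole organism (strain Charles Foster albino) for inhibition, with Rattus norvegicus as the target, read by paw edema, with stated times of 30 min and 3 h, at a dose of 50 mg/kg by the oral route; on this read-out lower numbers stand for less inhibition and higher numbers for more inhibition at the one dose given (going by the name of the read-out). In this assay compound 1 gives 15%, compound 3 gives 15%, and compound 2 gives 35%, the highest of the three, with both other values beyond the scatter below it. The difference between the core of compound 1 and the core of compound 2 is not broken down here.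

Compound 4 `CN(C)c1ccc(C2CC(c3cccnc3)=NN2c2ccccc2)cc1` has not yet been measured. It is related to compound 2 by pyridin-3-yl in place of pyridin-2-yl on a carbon with a double bond to nitrogen. Compound 3 is related to compound 1 by the same kind of change, (pyridin-3-yl in place of pyridin-2-yl on a carbon with a double bond to nitrogen); around the place the two differ in that compound 2 also carries a phenyl group two ring bonds from the site, while compound 1 carries a large group there. That earlier change gave no change at the digits printed from compound 1 to compound 3 (within the scatter). Because no change at the digits printed from compound 1 to compound 3 (within the scatter), a step of similar size is expected here, namely no change at the digits printed from compound 2 to compound 4 (within the scatter). Compound 4 is therefore estimated to give about 35%, with a likely range from 22% to 48%.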

Compound 4, a percentage reported as inhibition, in the whole organism at one dose (the size of the read-out at that dose, not a potency): 34%
Compound 4: the middle estimate sits 1 percentage points above what was measured; the range from low to high includes it.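

In this assay, putting pyridin-3-yl in place of pyridin-2-yl gives a number 1 percentage points lower from compound 2 to compound 4 (within the scatter). Set beside the same swap on the core of compound 1, the result carries over from one core to the other, with neither step standing out from the scatter: the same change on two cores in this assay, no change at the digits printed (within the scatter) from compound 1 to compound 3 and a number 1 percentage points lower (within the scatter) from compound 2 to compound 4, 1 percentage points apart, within the scatter of two such steps This shows that, on these two cores and at this single oral dose, the swap leaves the paw edema read-out where it was; it does not show that the same would hold on a third core or at another dose, and a result at one dose is not a measure of potency.

The compounds shown leave open whether pyridin-4-yl, or a group of another kind such as a carboxylic acid or an amine, would behave the same way on a carbon with a double bond to nitrogen of this ring. Within the data shown here, they also leave open how far this quiet result extends, since only two pyridinyl groups appear at that place, on only two cores.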